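The source may hold more compounds than are shown below. What is called first, only, known or untested is meant among the compounds shown, and "the series" means these compounds.

In an assay on isolated protein for binding affinity to corticotropin-releasing factor receptor 1 (Homo sapiens) (on this read-out higher numbers stand for weaker inhibition and lower numbers for stronger inhibition), compound 1 `C=Cc1ccccc1C(Nc1ccc(C)cc1Cl)C(=O)CCc1ccncc1` gives 752 nM; 752 nM (2 entries). Compound 2 `COc1cccc(C(Nc2ccc(C)cc2Cl)C(=O)CCc2ccncc2)c1` stands only at a limit: in this assay compound 2 gives > 10000 nM, a limit and not a number (the limit of > 10000 nM in this assay, at which 1 of the 2 values shown sits). Compound 3 `Cc1ccc(NC(C(=O)CCc2ccncc2)c2ccc(Cl)cc2)c(Cl)c1` carries 4-chlorophenyl in place of 3-methoxyphenyl on a saturated chain carbon bound to a carbonyl carbon and a nitrogen on an aromatic ring. Among the compounds with values here, no measured pair shares this change, so the size of the step is open; compound 1 shows that the shared core can reach a measured number, while the direction from compound 2 is unknown. In this assay the expected step is an at least 3.3-fold lower number from compound 2 to compound 3 (0.52 log units; beyond the scatter). Compound 3 is therefore estimated at 3000 nM in this assay, between 500 nM and 20000 nM, with a real chance that only a limit is returned again.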

Compound 3, inhibition constant: > 10000 nM
Compound 3: a limit, no number (the forecaster's own chance of this, stated with the estimate: 35%); middle value at least 3.3-fold (0.52 log units) from the limit.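

Compound 3 gives > 10000 nM in this assay, a limit and not a number, as does compound 2, so the step between them cannot be read. As far as these compounds go, whether 4-chlorophenyl or 3-methoxyphenyl gives stronger inhibition, and by how much, stays open.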